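The source may report more compounds than this note shows. Statements on the series, on what has been measured and on what is new or still open speak of the compounds shown alone.

- compound 1 `C=CNCc1cc(-c2c(C(=O)NCC)noc2-c2cc(C(C)C)c(O)cc2O)on1` gives 121 nM
- compound 2 `CCNC(=O)c1noc(-c2cc(C(C)C)c(O)cc2O)c1-c1cc(CN2CCCC2)no1` gives 51 nM

Both values come from a functional assay on HCT-116 cells (Homo sapiens) for inhibition (a lower number here means a stronger inhibitor, a higher number a weaker inhibitor), and compound 2 has the lower number of the pair, which makes it the stronger inhibitor of the two. Compound 3 `CCNC(=O)c1cc(-c2c(C(=O)NCC)noc2-c2cc(C(C)C)c(O)cc2O)on1` carries ethylcarbamoyl in place of (pyrrolidin-1-yl)methyl on an aromatic carbon and is still unmeasured. Going by the values given here, one measured step bears on this group, a 2.4-fold lower number from compound 1 to compound 2 (0.38 log units; beyond the scatter), which is modest and changes only the amine part of the group. Among the compounds with values here, no measured compound has ethylcarbamoyl at this place, so that step is a rough guide to size only. With the group of compound 2 gone, a modest step towards a higher number seems likely, back towards compound 1 at 121 nM in this assay. The expected change is a 2.0-fold higher number from compound 2 to compound 3 (0.29 log units; within the scatter). For compound 3 the estimated value is 100 nM, with an expected range from 35 nM to 280 nM.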

Compound 3, half-maximal inhibitory concentration: 14 nM
Beside the measured number, compound 3's estimate is 7.1-fold (0.85 log units) above it; measured number below the stated range.
By their numbers in this assay, from the lowest: compound 3; then compound 2; then compound 1.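

Swapping (pyrrolidin-1-yl)methyl for ethylcarbamoyl on this aromatic carbon, next to the ring nitrogen, gives a 3.6-fold lower number from compound 2 to compound 3 (0.56 log units; beyond the scatter) in this assay, so this place tolerates more than small changes within an amine side chain. Replacing the (vinylamino)methyl group with ethylcarbamoyl gives an 8.6-fold lower number from compound 1 to compound 3 (0.94 log units; beyond the scatter), which shows that among these three compounds the stronger inhibition at this place does not depend on an amine attached through a chain carbon. No supporting evidence is available to explain this result.

The compounds shown do not separate the contributions of the carbonyl, the amide hydrogen and the ethyl chain of the new group. A methyl amide, a longer chain on the amide nitrogen, an ester or a carboxylic acid at this place would probe these parts one at a time.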